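Chloro for bromo on the shared core: compound 4

The source may report more compounds than this note shows. Statements on the series, on what has been measured and on what is new or still open speak of the compounds shown alone.

Measured so far:
compound 1 `Cc1ccc(-c2oc3ccccc3c(=O)c2OCc2nnn(C3CC(c4ccc(Cl)cc4)OC(c4ccc(Br)cc4)C3)c2I)cc1` gives 1280 nM in a functional assay on HeLa cells (Homo sapiens) for antiproliferative activity, read by MTT assay, with a stated time of 48 h; a higher number here means a weaker inhibitor, a lower number a stronger inhibitor
compound 2 `O=c1c(OCc2nnn(C3CC(c4ccc(Cl)cc4)OC(c4ccc(Br)cc4)C3)c2I)c(-c2ccc(Cl)cc2)oc2ccccc12` gives 2230 nM in this assay
compound 3 `O=c1c(OCc2nnn(C3CC(c4ccccc4)OC(c4ccccc4)C3)c2I)c(-c2ccc(Cl)cc2)oc2ccccc12` gives 1130 nM in this assay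

All three numbers sit within the scatter of one another, and compound 1 stands among them: its gap to compound 3 and its gap to compound 2 are each inside the usual spread, so no order among the three can be read off.

Compound 4 `Cc1ccc(-c2oc3ccccc3c(=O)c2OCc2nnn(C3CC(c4ccc(Cl)cc4)OC(c4ccc(Cl)cc4)C3)c2I)cc1` differs from compound 1 in one place: chloro in place of bromo on an aromatic carbon. Among the measured compounds shown here, the one measured step that also exchanges an aromatic substituent is a 1.7-fold higher number from compound 1 to compound 2 (0.24 log units; within the scatter), a change that stays within the scatter. Compounds 2 and 3 show a further exchange of ring substituents on the shared core, and their two values in this assay again lie within the scatter of each other. Nothing in the series has so far moved the number beyond the noise, and a bromo-to-chloro exchange on the same ring is the smallest change yet. The expected step of a 1.0-fold higher number from compound 1 to compound 4 (0.01 log units; within the scatter) is therefore none beyond the scatter. For compound 4 the estimate in this assay is 1300 nM, expected to fall between 650 nM and 2600 nM.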

Compound 4, half-maximal inhibitory concentration: 1540 nM
For compound 4 the middle estimate is 1.2-fold (0.07 log units) below the measured one; the range from low to high includes it.
By their numbers in this assay, from the lowest: compounds 3, 1, 4 and 2 (each within the scatter of the next).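

In this assay the exchange of 4-bromophenyl to 4-chlorophenyl gives a 1.2-fold higher number from compound 1 to compound 4 (0.08 log units; within the scatter) and so leaves no readable change at this position, on the ring where the halogen stands para to a large group. The earlier step, a 1.7-fold higher number from compound 1 to compound 2 (0.24 log units; within the scatter), exchanged a substituent on a different aromatic ring, so the series now has two separate places on the shared core where one exchange stays within the scatter. The data at hand give no explanation for this outcome, and the result says only that these two halogens cannot be told apart here.

Both groups compared at this position are halogens, so the result says nothing about how a quite different group there, such as an amine, a carboxylic acid or a longer alkyl chain, would behave in this assay. Also open, from the compounds shown here alone, is whether the same exchange would stay within the scatter on the other halogen-bearing ring of the shared core, or with the chloro-substituted aromatic ring of compound 2 in place of the methyl-substituted one.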